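Reading a dimethylamino swap without a baseline

This account rests on a few compounds, and the source may have more. Where it says the series, first, only, none or still open, it means among the compounds named here.

Measured compounds so far:
compound 1 `COc1ccc(/C=C/C=C/C(=O)c2ccc(F)cc2)cc1`: "not determined" (no result reported)
compound 2 `COc1ccc(/C=C/C=C/C(=O)c2ccc(C)s2)cc1`: "not determined" (no result reported)
compound 3 `COc1ccc(/C=C/C=C/C(=O)c2cccs2)cc1`: 68500 nM

The test here is an ADME assay on RAW264.7 cells (Mus musculus) for cytotoxicity, read by MTT assay; on this read-out higher numbers stand for weaker inhibition and lower numbers for stronger inhibition. In this assay compound 1 has no single number, and its entry reads "not determined" (no result reported). The same holds for compound 2, which also shows "not determined" (no result reported). Within the data shown here, only compound 3 gives a figure, at 68500 nM, so the series has one firm reference point and no measured step between any two compounds.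

The next compound to be tested is compound 4 `CN(C)c1ccc(/C=C/C=C/C(=O)c2ccc(F)cc2)cc1`, which is built from compound 1 by a single change: dimethylamino in place of methoxy on an aromatic carbon. In words, dimethylamino stands in place of methoxy on an aromatic carbon, para to a large group; the rest of the structure stays the same.

Without a number for compound 1, the size of this change in this assay cannot be read directly. A modest step towards a lower number is expected, not far beyond the usual scatter of repeat measurements. The estimate therefore leans on compound 3 at 68500 nM, the only figure available, and it stays wide.

For compound 4 the expected value is 40000 nM, with an estimated range from 10000 nM to 120000 nM.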

Compound 4, half-maximal inhibitory concentration: > 100000 nM
Compound 4 was reported as a limit; the forecaster's own chance of this, stated with the estimate: 25%; middle value at least 2.5-fold (0.39 log units) away from the limit.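

In this assay the result for compound 4 is a limit and not a number: the limit of > 100000 nM in this assay, at which 1 of the 4 values shown sits. Among these compounds, compound 1 has no single number, so no step between compound 1 and compound 4 can be read. The compounds shown leave open how far dimethylamino in place of methoxy shifts the result in this assay.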